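Benzylidene semicarbazide series: notes toward compound 4

The source may hold more compounds than are shown below. What is called first, only, known or untested is meant among the compounds shown, and "the series" means these compounds.

The compounds share one core, seen in compound 1 `CN(C)CCn1cnnc1-c1cc(Oc2ccc(NC(=O)N/N=C/c3cc(Br)c(O)c(Br)c3)cc2F)ccn1`. In a functional assay on U-87MG ATCC cells (Homo sapiens) for cytotoxicity, read by MTT assay, with a stated time of 72 h (on this read-out lower numbers stand for stronger inhibition and higher numbers for weaker inhibition), compound 1 gives only a limit, > 100000 nM. Compound 2 `Cn1ncnc1-c1cc(Oc2ccc(NC(=O)N/N=C/c3ccccc3)cc2F)ccn1` also reaches only a limit in this assay, > 100000 nM. For the measured compounds named here, compound 3 `Cn1cnnc1-c1cc(Oc2ccc(NC(=O)N/N=C/c3ccccc3)cc2F)ccn1` is the one compound with a number, 36300 nM in this assay. Going by the values given here, the single measured step is an at least 2.7-fold lower number from compound 2 to compound 3 (0.44 log units; beyond the scatter), and it concerns the triazole on the core, not the benzylidene part. Two of the three values sit at the limit, (the limit of > 100000 nM in this assay, at which 2 of the 3 values shown sit), so compound 1 stands no better than the weak end of what has been measured.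

Compound 4 `CN(C)CCn1cnnc1-c1cc(Oc2ccc(NC(=O)N/N=C/c3ccc(F)cc3F)cc2F)ccn1` differs from compound 1 at the benzylidene end: 2,4-difluorophenyl in place of 3,5-dibromo-4-hydroxyphenyl on a carbon with a double bond to nitrogen. No measured step touches this position, so the size and direction of the change cannot be read from the steps shown; the step between the triazoles does not bear on it. With the parent at a limit and most of the series at a limit, the expectation for compound 4 in this assay is a weak value, and the expected step of an at least 1.2-fold lower number from compound 1 to compound 4 (0.09 log units; that floor lies within the scatter) is set near nothing beyond the scatter, with the chance that only a limit is reported again. Compound 4 is estimated at 80000 nM, in the range 25000 nM to 250000 nM.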

Compound 4, half-maximal inhibitory concentration: 1900 nM
Compound 4: middle estimate off by 42-fold (1.62 log units), on the high side; the measured number lies below the stated range.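

For the compounds shown here, the benzylidene end, on a carbon with a double bond to nitrogen, proves to be a position that strongly moves the read-out in this assay: 2,4-difluorophenyl in place of 3,5-dibromo-4-hydroxyphenyl gives an at least 52-fold lower number from compound 1 to compound 4 (1.72 log units; beyond the scatter), whereas the earlier compounds offered a measured step only at the triazole. Compound 4 also carries the dimethylaminoethyl chain of compound 1 and still gives a number, so that chain does not by itself hold a compound at the limit. The step is a floor and not a full size, since the value for compound 1 is only a limit: the limit of > 100000 nM in this assay, at which 2 of the 4 values shown sit.

The change removes both bromines and the hydroxyl and adds both fluorines at once, so the compounds shown do not tell which of these parts accounts for the step, and groups such as 4-methoxyphenyl or 3,5-dichlorophenyl at this position would help to separate them. From the compounds shown here alone, whether 2,4-difluorophenyl gives a similar gain with the methyl-bearing triazoles of compound 2 and compound 3 also remains open.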